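Ring-substituted cyclic hydrazide series: expectation for methoxy analogue

The source may hold more compounds than are shown below. What is called first, only, known or untested is meant among the compounds shown, and "the series" means these compounds.

Measured so far in an assay on isolated protein for inhibition of Polyunsaturated fatty acid 5-lipoxygenase (Homo sapiens); a lower number here means a stronger inhibitor, a higher number a weaker inhibitor:
compound 1 `Cc1ccccc1N1CCCC(=O)N1` gives 57000 nM
compound 2 `CCc1cccc(N2CCCC(=O)N2)c1` gives 3000 nM
compound 3 `O=C1CCCN(c2cccc(Cl)c2)N1` gives 2500 nM

Compound 1 stands at the highest of the three numbers in this assay; compound 2 lies at a lower number, and compound 3 at a lower number still, both gaps beyond the scatter. Among the measured compounds shown here, the one step that can be read between two compounds differing in one place, a 1.2-fold lower number from compound 2 to compound 3 (0.08 log units; within the scatter), concerns a substituent on the shared core at a different site and swaps chloro for ethyl; it gives no direct guidance on the present change.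

Compound 4 `COc1ccccc1N1CCCC(=O)N1` differs from compound 1 by methoxy in place of methyl on an aromatic carbon. For the measured compounds named here, no measured pair in this assay shares that change, so there is no step to scale it from. The expectation is therefore for little movement: compound 4 is expected to remain near compound 1, with a step of a 1.9-fold lower number from compound 1 to compound 4 (0.28 log units; within the scatter) that is not confidently beyond the scatter in either direction. Pending measurement, compound 4 is estimated at 30000 nM in this assay, with a range from 8000 nM to 110000 nM.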

Compound 4, half-maximal inhibitory concentration: 204000 nM
The estimate for compound 4 lay 6.8-fold (0.83 log units) below the measured number; the whole stated range lies below it.
By their numbers in this assay, from the lowest: compounds 3 and 2 (each within the scatter of the next); then compound 1; then compound 4.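

In this assay the position ortho to a group of 7 heavy atoms is sensitive to the substituent: methoxy in place of methyl gives a 3.6-fold higher number from compound 1 to compound 4 (0.55 log units; beyond the scatter) and this step lies beyond the scatter. Among the compounds shown here, this is the first readable step at this position, since the only earlier step, from ethyl to chloro, concerns a different site on the shared core. Methoxy brings one more heavy atom and a hydrogen-bond acceptor, but a single pair cannot separate the contributions of these two differences, and no measured evidence explains the direction of the step.

Still open, going by these compounds, is how other groups at this position would rank against methyl and methoxy, for example a hydroxyl, an amine, a chloro or a longer chain such as ethoxy. Also open, on these data alone, is whether methoxy would give a step of similar direction and size at the site that carries the ethyl of compound 2 and the chloro of compound 3.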